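Branched Alkyl Cyanoguanidines Tested in Hypertensive Rats

The source may report more compounds than this note shows. Statements on the series, on what has been measured and on what is new or still open speak of the compounds shown alone.

Compound 1, `CCC(C)/N=C(\NC#N)Nc1cccnc1`: 20 mg/kg
Compound 2, `CC(C)C(C)(C)/N=C(\NC#N)Nc1cccnc1`: 1 mg/kg
Compound 3, `CC(C)(C)C/N=C(\NC#N)Nc1ccncc1`: 5 mg/kg

Of the compounds shown here, three have been measured in a functional assay on the whole organism (blood, strain Wistar-Okamoto) with Rattus norvegicus as the target, with a stated time of 5 days; a lower number here means that less compound is needed, a higher number that more compound is needed for the effect. Compound 3 stands second highest of the three; compound 1 gives 20 mg/kg and compound 2 gives 1 mg/kg. Compound 4, `CC(C)(C)/N=C(\NC#N)Nc1ccncc1`, has not yet been measured. It differs from compound 3 as follows: tert-butyl in place of neopentyl on a double-bonded nitrogen. For the measured compounds named here, the only measured step, a 20-fold lower number from compound 1 to compound 2 (1.30 log units; beyond the scatter), concerns a different pair of groups on a different core, so it bears on this change only loosely; it shows that a more branched group on the double-bonded nitrogen can lower the number strongly. Compound 4 is therefore expected to show a modest step, a 1.7-fold lower number from compound 3 to compound 4 (0.22 log units; within the scatter), and its estimated value is 3 mg/kg, in the range 1 mg/kg to 10 mg/kg.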

Compound 4, minimum effective dose: 2.5 mg/kg
Beside the measured number, compound 4's estimate is 1.2-fold (0.08 log units) above it, within the range that was stated.
By their numbers in this assay, from the lowest: compound 2; then compounds 4 and 3 (each within the scatter of the next); then compound 1.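

In this assay, tert-butyl in place of neopentyl on a double-bonded nitrogen gives a 2.0-fold lower number from compound 3 to compound 4 (0.30 log units; within the scatter), so this change does not move the number beyond the scatter. The earlier step, a 20-fold lower number from compound 1 to compound 2 (1.30 log units; beyond the scatter), lay on a different core and showed a large shift, whereas this pair shows that exchanging one branched group for another at this place need not produce one. Nothing measured here accounts for this result.

The compounds shown leave open how a longer chain, a cyclohexyl group or an amine would behave at this place. They also leave open what 1,1,2-trimethylpropyl would give on the core of compound 3.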